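Benzylamide in place of anilide on the shared core

The source may hold more compounds than are shown below. What is called first, only, known or untested is meant among the compounds shown, and "the series" means these compounds.

Compound 2 `COc1ccc2c(=O)c(/C=C/C(=O)Nc3cc(C)ccc3C)coc2c1` gives in an ADME assay on HepG2 2.2.15 cells (Homo sapiens) for cytotoxicity, read by MTT assay, with stated times of 48 h and 9 days (on this read-out lower numbers stand for higher toxicity in this test and higher numbers for lower toxicity in this test), a value of 1100000 nM, the highest of the three numbers measured. Compound 3 `O=C(/C=C/c1coc2cc(O)ccc2c1=O)NCc1ccccc1` gives 436000 nM and compound 1 `O=C(/C=C/c1coc2cc(O)ccc2c1=O)NCc1ccc(F)cc1` gives 357000 nM; both differ from compound 2 in more than one place, so only their values can be set beside it. Compound 4 `COc1ccc(CNC(=O)/C=C/c2coc3cc(OC)ccc3c2=O)cc1` is unmeasured and differs from compound 2 by 4-methoxybenzyl in place of 2,5-dimethylphenyl on an amide-type nitrogen. Within the data shown here, the one measured single step, a 1.2-fold higher number from compound 1 to compound 3 (0.09 log units; within the scatter), swaps hydrogen for fluoro on an aromatic carbon and does not cover an aryl-for-benzyl exchange on the nitrogen, so the direction rests on the lower values of compounds 1 and 3 alone. The expected step is a 1.6-fold lower number from compound 2 to compound 4 (0.20 log units; within the scatter), leaning toward a lower number with wide uncertainty. Compound 4 is therefore estimated at 700000 nM, between 300000 nM and 1500000 nM.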

Compound 4, half-maximal cytotoxic concentration: 43000 nM
Compound 4: middle estimate off by 16-fold (1.21 log units), on the high side; measured number below the stated range.
By their numbers in this assay, from the lowest: compound 4; then compounds 1 and 3 (each within the scatter of the next); then compound 2.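

On the amide-type nitrogen, the exchange of 2,5-dimethylphenyl for 4-methoxybenzyl is far from neutral in this assay (a 26-fold lower number from compound 2 to compound 4 (1.41 log units; beyond the scatter)). This place can therefore move the number well beyond the scatter, which the earlier hydrogen-for-fluoro step on an aromatic carbon (a 1.2-fold higher number from compound 1 to compound 3 (0.09 log units; within the scatter)) did not show. No measurement at hand explains the size of this step.

Among these compounds, the single step changes the whole group, so the shares of the benzyl link, the methoxy group and the lost methyl groups remain unresolved. As far as these compounds go, how a 2-phenylethyl group or an aminoalkyl chain on this nitrogen would read also remains open.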